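The compounds below may be only part of what the source reports. "The series", "measured", "known", "first", "only" and "open" are said of these compounds alone.

- Compound 1 `CCOC(=O)C(=O)Nc1cccc(N(C)C)c1C#N`: 0.2 mg/kg
- Compound 2 `CCOC(=O)C(=O)Nc1cccc(N(CC)CC)c1C#N`: 0.7 mg/kg

In a functional assay on the whole organism with Rattus norvegicus as the target (on this read-out higher numbers stand for an effect only at larger amounts of compound and lower numbers for an effect already at smaller amounts), compound 2 has the higher number of the two measured, at 0.7 mg/kg. Compound 3 `CCOC(=O)C(=O)Nc1cccc(C)c1C#N` has methyl in place of diethylamino on an aromatic carbon. Among the measured compounds shown here, only one measured step bears on this, a 3.5-fold higher number from compound 1 to compound 2 (0.54 log units; beyond the scatter), a modest change that swaps dimethylamino for diethylamino at the same place. For the measured compounds named here, no measured compound carries methyl there, so the expectation is loose, but a modest move to a lower number seems likeliest. The expected change is a 1.8-fold lower number from compound 2 to compound 3 (0.24 log units; within the scatter). For compound 3 the estimated value is 0.4 mg/kg, with an expected range of 0.1 mg/kg to 1.5 mg/kg.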

Compound 3, dose for half-maximal effect: 5.3 mg/kg
Beside the measured number, compound 3's estimate is 13-fold (1.12 log units) below it, outside the stated range (above it).
By their numbers in this assay, from the lowest: compound 1; then compound 2; then compound 3.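

In this assay, replacing either amino group with methyl, which holds no nitrogen, gives a 7.6-fold higher number from compound 2 to compound 3 (0.88 log units; beyond the scatter) and a 27-fold higher number from compound 1 to compound 3 (1.42 log units; beyond the scatter). This position therefore tolerates a change between the two amino groups better than the loss of the amino group altogether, and among these compounds both amino groups give lower numbers than methyl, with no exception. No measured evidence explains this difference. The compounds shown leave open whether the nitrogen itself or the size of the group matters. A methoxy group, an unsubstituted amine or a longer carbon chain here could help separate the two.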